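Methoxy for fluoro on the benzamide ring of compound 3

The source may report more compounds than this note shows. Statements on the series, on what has been measured and on what is new or still open speak of the compounds shown alone.

Measured compounds:
compound 1, `CCN(CCn1ccc(-c2cccc(C(F)(F)F)n2)n1)C(=O)c1cc(C)ccc1-n1nccn1`: 3.92 nM
compound 2, `Cc1ccc(-n2nccn2)c(C(=O)N(CCn2ccc(-c3ccc(F)cn3)n2)C(C)C)c1`: 37.9 nM
compound 3, `CCN(CCn1ccc(-c2ccc(F)cn2)n1)C(=O)c1cc(F)ccc1-n1nccn1`: 11.4 nM

All three values come from a functional assay on CHO cells for antagonist activity at Orexin receptor type 2 (Homo sapiens), read by fluorescence and calcium flux, with a stated time of 30 min; on this read-out higher numbers stand for weaker inhibition and lower numbers for stronger inhibition. Compound 3 gives 11.4 nM in this assay and holds the second highest of the three numbers: compound 1 sits at a lower number, a gap beyond the scatter, while compound 2 sits at a higher number, also beyond the scatter. Going by the values given here, no step between two measured compounds differing in a single place is available in this set, so the effect of a substituent swap on the benzamide ring has not been isolated.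

Compound 4, `CCN(CCn1ccc(-c2ccc(F)cn2)n1)C(=O)c1cc(OC)ccc1-n1nccn1`, is the next entry. It differs from compound 3 in one place: methoxy in place of fluoro on an aromatic carbon, placed meta to a large group and para to the 2H-1,2,3-triazol-2-yl group. Among the compounds with values here, with no single-change step on record, the expected size of the step from compound 3 to compound 4 is small, not beyond the scatter in either direction, estimated as a 1.0-fold lower number from compound 3 to compound 4 (0.02 log units; within the scatter). Compound 4 is therefore expected to give about 11 nM in this assay, with a range from 3.5 nM to 35 nM.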

Compound 4, antagonist equilibrium constant: 638 nM
Compound 4: middle estimate off by 58-fold (1.76 log units), on the low side; the whole stated range lies below it.
By their numbers in this assay, from the lowest: compound 1; then compound 3; then compound 2; then compound 4.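

Methoxy in place of fluoro on this aromatic carbon, para to a 2H-1,2,3-triazol-2-yl group, gives a 56-fold higher number from compound 3 to compound 4 (1.75 log units; beyond the scatter) in this assay, and this is the only single-place step in the set. It shows that this position is far from indifferent to its substituent: the change alone moves compound 4 well past every other number in the series, including that of compound 2. No measurement at hand bears on why the step is so large.

As far as these compounds go, what remains open is whether the loss follows from the oxygen or from the added carbon of the methoxy. From the compounds shown here alone, it is also open how a hydroxy, an ethoxy or a chloro on this carbon of the compound 3 scaffold would read, and whether the step holds with other groups elsewhere on the core.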